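The source may hold more compounds than are shown below. What is called first, only, known or untested is meant among the compounds shown, and "the series" means these compounds.

Measured so far:
- compound 1, `C=C1[C@@H](OC(C)=O)C[C@@H]2[C@](C)(CO[Si](C)(C)C(C)(C)C)[C@H](OC(C)=O)CC[C@@]2(C)[C@@H]1C[C@@H](Nc1ccccc1)C1=CCOC1=O`: 4050 nM
- compound 2, `C=C1[C@@H](OC(C)=O)C[C@@H]2[C@](C)(CO[Si](C)(C)C(C)(C)C)[C@H](OC(C)=O)CC[C@@]2(C)[C@@H]1C[C@@H](Nc1ccccc1F)C1=CCOC1=O`: 3710 nM
- compound 3, `C=C1[C@@H](OC(C)=O)C[C@@H]2[C@](C)(COC=O)[C@H](OC(C)=O)CC[C@@]2(C)[C@@H]1C[C@@H](Nc1ccc(Br)cc1)C1=CCOC1=O`: 13200 nM

In a functional assay on HT-29 cells (Homo sapiens) for cytotoxicity, read by sulforhodamine B assay (on this read-out higher numbers stand for weaker inhibition and lower numbers for stronger inhibition), compound 3 gives the highest of the three numbers, a weaker inhibitor than compound 1 and compound 2 by a margin beyond the scatter. Compound 4, `C=C1[C@@H](OC(C)=O)C[C@@H]2[C@](C)(COC=O)[C@H](OC(C)=O)CC[C@@]2(C)[C@@H]1C[C@@H](Nc1ccccc1C(=O)O)C1=CCOC1=O`, is the next compound to be measured in this assay. It differs from compound 3 in one place: 2-carboxyphenyl in place of 4-bromophenyl on an amine nitrogen.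

Going by the values given here, only one measured step concerns a change on this aromatic ring, and it is the one that gives a 1.1-fold lower number from compound 1 to compound 2 (0.04 log units; within the scatter). That step swaps a hydrogen for a fluorine, a far smaller change than the present exchange of a bromine for a carboxyl group, so it says little about what to expect here. Among the compounds with values here, no measured pair shows what a carboxyl group on this ring does. With compound 3 as the only anchor, the step of a 1.1-fold higher number from compound 3 to compound 4 (0.06 log units; within the scatter) is therefore expected to be small and uncertain in direction. Compound 4 is estimated at 15000 nM, within a range of 5000 nM to 45000 nM.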

Compound 4, half-maximal inhibitory concentration: 28700 nM
Compound 4: the middle estimate sits 1.9-fold (0.28 log units) below what was measured; low and high end bracket the measured number.
By their numbers in this assay, from the lowest: compounds 2 and 1 (each within the scatter of the next); then compound 3; then compound 4.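

In this assay, 2-carboxyphenyl in place of 4-bromophenyl on the amine nitrogen gives a 2.2-fold higher number from compound 3 to compound 4 (0.34 log units; beyond the scatter), so a change on this aromatic ring can move the number by more than the scatter, which the earlier fluoro step, a 1.1-fold lower number from compound 1 to compound 2 (0.04 log units; within the scatter), did not show. This step is modest, and because the two groups differ in both the substituent and its place on the ring, it cannot be assigned to either alone. Nothing available accounts for the direction or size of this step.

The compounds shown leave open whether a 2-bromophenyl or a 4-carboxyphenyl group would separate those two changes, and whether a methyl ester or an amide of the carboxylic acid would keep the higher number. They also leave open whether 2-carboxyphenyl would give a similar step on the core of compound 1.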